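The source may report more compounds than this note shows. Statements on the series, on what has been measured and on what is new or still open speak of the compounds shown alone.

Measured compounds:
- compound 1, `C=CC1=C(C(=O)NCCCCC)C(c2ccc(OC)cc2)OC1`: 36500 nM
- compound 2, `C=CC1=C(C(=O)NCCC)C(c2ccc(Cl)c(Cl)c2)OC1`: > 100000 nM
- compound 3, `C=CC1=C(C(=O)NCc2ccccc2F)C(c2ccc(F)cc2)OC1`: > 100000 nM

Going by the values given here, in a functional assay on A549 cells (Homo sapiens) for cytotoxicity, read by MTT assay, with a stated time of 24 h (on this read-out higher numbers stand for weaker inhibition and lower numbers for stronger inhibition), compound 1 gives 36500 nM, the only numerical value among the three measured compounds. Compound 2 reaches only a limit of the assay, > 100000 nM. Compound 3 likewise reaches only a limit, > 100000 nM. Among the compounds with values here, two of the three values therefore sit at the limit of > 100000 nM in this assay, at which 2 of the 3 values shown sit, and compound 1 stands as the one compound with a number to its name; no step between two numbers is available to guide expectations.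

The unmeasured compound 4, `C=CC1=C(C(=O)Nc2ccc(C)cc2)C(c2ccc(OC)cc2)OC1`, is reached from compound 1 by a single change: 4-methylphenyl in place of pentyl on an amide-type nitrogen. Within the data shown here, since no measured pair shows what such a change does in this assay, there is no basis for expecting a step in either direction beyond the usual scatter. Compound 4 is therefore expected to give about 40000 nM, within a range from 12000 nM to 130000 nM. The step this estimate means, a 1.1-fold higher number from compound 1 to compound 4 (0.04 log units; within the scatter), is expected to lie within the scatter of repeated measurements.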

Compound 4, half-maximal inhibitory concentration: > 100000 nM
Compound 4 was reported as a limit; the forecaster's own chance of this, stated with the estimate: 30%; middle value at least 2.5-fold (0.39 log units) from the limit.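

In this assay, the amide-type nitrogen now shows a first readable effect of a single change, as 4-methylphenyl in place of pentyl gives an at least 2.7-fold higher number from compound 1 to compound 4 (0.43 log units; beyond the scatter) and so lies beyond the scatter. Going by these compounds alone, on the core of compound 1, then, this aromatic ring in place of the open chain weakens inhibition, leaving compound 1 as the only compound with a number. The value of compound 4, > 100000 nM, is a limit and not a number, so the step gives only a lower bound on the true difference: the limit of > 100000 nM in this assay, at which 3 of the 4 values shown sit.

Going by these compounds, whether a hexyl chain, an unsubstituted phenyl or a cyclohexyl on this nitrogen would give a numerical value remains open. Also open, on these data alone, is whether the same exchange has a similar effect on the other aryl-substituted compounds, whose values are limits too.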